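This account rests on a few compounds, and the source may have more. Where it says the series, first, only, none or still open, it means among the compounds named here.

Working notes on the series.

Three analogues on a shared core are in hand: compound 1 `FC(F)(F)c1ccc(CSc2nc(Nc3cccc(Cl)c3)c3ccccc3n2)cc1`, compound 2 `FC(F)(F)c1ccc(CSc2nc(Nc3cccc(Br)c3)c3ccccc3n2)cc1` and compound 3 `FC(F)(F)c1ccc(CSc2nc(Nc3ccc(Cl)cc3)c3ccccc3n2)cc1`. In a functional assay on MCF7 cells (Homo sapiens) for cytotoxicity, read by MTT assay, with a stated time of 72 h (a higher number here means a weaker inhibitor, a lower number a stronger inhibitor), compound 1 gives 25100 nM, compound 2 gives 25600 nM and compound 3 gives 21500 nM. The steps among them, a 1.0-fold higher number from compound 1 to compound 2 (0.01 log units; within the scatter), a 1.2-fold lower number from compound 1 to compound 3 (0.07 log units; within the scatter) and a 1.2-fold lower number from compound 2 to compound 3 (0.08 log units; within the scatter), all fall within the scatter, so the three numbers cannot be separated; compound 2 carries the largest of the three only nominally.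

Compound 4 `Fc1ccc(Nc2nc(SCc3ccc(C(F)(F)F)cc3)nc3ccccc23)cc1Cl` has not been measured. Against compound 2 the change is 3-chloro-4-fluorophenyl in place of 3-bromophenyl on a nitrogen on an aromatic ring. For the measured compounds named here, two measured steps bear on it: the halogen swap a 1.0-fold higher number from compound 1 to compound 2 (0.01 log units; within the scatter) and the move of a halogen around the phenyl ring a 1.2-fold lower number from compound 2 to compound 3 (0.08 log units; within the scatter); neither left the scatter. Going by the values given here, a second halogen on that ring has no precedent here. The expected step is therefore a 1.1-fold lower number from compound 2 to compound 4 (0.03 log units; within the scatter), no change beyond the scatter in either direction. The estimate for compound 4 in this assay is 24000 nM, with a range from 10000 nM to 55000 nM.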

Compound 4, half-maximal inhibitory concentration: 23000 nM
The estimate for compound 4 lay 1.0-fold (0.02 log units) above the measured number, and the stated range covers the measured number.
By their numbers in this assay, from the lowest: compounds 3, 4, 1 and 2 (each within the scatter of the next).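

Fluoro in place of hydrogen on an aromatic carbon, the one change that adds a second halogen to the ring on this nitrogen, gives a 1.1-fold lower number from compound 1 to compound 4 (0.04 log units; within the scatter) in this assay. The 3-chloro-4-fluorophenyl group also cannot be separated from the two other groups it replaces at this position, with a 1.1-fold lower number from compound 2 to compound 4 (0.05 log units; within the scatter) and a 1.1-fold higher number from compound 3 to compound 4 (0.03 log units; within the scatter), so a ring with two halogens reads the same here as a ring with one. Nothing measured bears on why these numbers stay together.

Going by these compounds, all four compounds carry only halogens on this ring, so it remains open whether a methoxy group, an amine or a carboxylic acid there would move the number beyond the scatter. On these data alone, the trifluoromethyl group is common to all four, and the effect of a nitrile in its place is equally open.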